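This account rests on a few compounds, and the source may have more. Where it says the series, first, only, none or still open, it means among the compounds named here.

Working notes on the series. Compound 1 `NC(=O)[C@@H](c1ccccc1)N(C(=O)c1ccccc1)[C@@H]1CCc2ccccc21` is the parent without a substituent on the fused aromatic ring; in an assay on HEK293T cells for antagonist activity at transient receptor potential cation channel subfamily M member 8 (Homo sapiens), read by fluorescence and calcium flux, with a stated time of 60 min (on this read-out higher numbers stand for weaker inhibition and lower numbers for stronger inhibition), compound 1 gives 270 nM. Compound 2 `NC(=O)[C@@H](c1ccccc1)N(C(=O)c1ccccc1)[C@@H]1CCc2ccc(Cl)cc21` adds a chloro on that ring, and in this assay compound 2 gives 120 nM. Compound 3 `NC(=O)[C@@H](c1ccccc1)N(C(=O)c1ccccc1)[C@@H]1CCc2c(F)cccc21` adds a fluoro on that ring at a different carbon, and in this assay compound 3 gives 120 nM. The two substitutions gave steps of equal size: a 2.3-fold lower number from compound 1 to compound 2 (0.35 log units; beyond the scatter) and a 2.3-fold lower number from compound 1 to compound 3 (0.35 log units; beyond the scatter). On these numbers compound 3 stands level with compound 2 at the digits shown, the pair together at the low end of the three, with compound 1 the one farthest away from compound 3.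

The next step goes to compound 4 `NC(=O)[C@@H](c1ccccc1)N(C(=O)c1ccccc1)[C@@H]1CCc2c(Cl)cccc21`, where the change is chloro in place of fluoro on an aromatic carbon. Among the measured compounds shown here, no measured step compares chloro with fluoro at the same carbon. What bears on it is that a chloro in compound 2 and a fluoro in compound 3 each gave the same modest step from compound 1 quoted above, so the two halogens have so far behaved alike. The step expected here is a 1.2-fold lower number from compound 3 to compound 4 (0.08 log units; within the scatter), within the scatter. In this assay compound 4 is estimated at 100 nM, with a range from 40 nM to 250 nM.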

Compound 4, half-maximal inhibitory concentration: 720 nM
For compound 4 the middle estimate is 7.2-fold (0.86 log units) below the measured one; measured number above the stated range.
By their numbers in this assay, from the lowest: compounds 2 and 3 (each within the scatter of the next); then compound 1; then compound 4.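

Among the compounds shown here, at this aromatic carbon, ortho to a fused ring and meta to a fused ring, chloro and fluoro do not read alike in this assay: the exchange gives a 6.0-fold higher number from compound 3 to compound 4 (0.78 log units; beyond the scatter), so the match between the two halogens in the earlier compounds does not extend to a comparison at one carbon. Chloro in place of hydrogen here also runs in the opposite direction to the earlier halogen steps, with a 2.7-fold higher number from compound 1 to compound 4 (0.43 log units; beyond the scatter) against a 2.3-fold lower number from compound 1 to compound 3 (0.35 log units; beyond the scatter) for fluoro at this carbon, and the printed values separate the two chloro placements, with compound 2 at 120 nM and compound 4 at 720 nM, so the outcome of a chloro on this ring depends on the carbon that carries it. No measurement available here accounts for this reversal.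

Open, from the compounds shown here alone, is how a bromo, a methyl or a methoxy at this carbon would read against fluoro and chloro. Also open, going by these compounds, is how a fluoro would read on the carbon that carries the chloro in compound 2, which would show whether the difference between the halogens is confined to this carbon.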